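The compounds below may be only part of what the source reports. "The series", "measured", "known", "first", "only" and "open" are said of these compounds alone.

Series notes. Going by the values given here, compound 2 `OC(c1ccccc1)(c1ccccc1)C1CCN(C(=S)Nc2ccc(C(F)(F)F)cc2)CC1` carries a 4-(trifluoromethyl)phenyl on the thiourea nitrogen; in a functional assay for antagonist activity at Neuropeptide Y receptor type 2 (Homo sapiens) (on this read-out lower numbers stand for stronger inhibition and higher numbers for weaker inhibition), compound 2 gives 178 nM, the second highest of the three numbers so far. Compound 1 `OC(c1ccccc1)(c1ccccc1)C1CCN(C(=S)Nc2ccc(OC(F)(F)F)cc2)CC1` gives 1050 nM in this assay, and compound 3 `CCN(CC)c1ccc(NC(=S)N2CCC(C(O)(c3ccccc3)c3ccccc3)CC2)cc1` gives 72 nM. The recorded steps are a 5.9-fold lower number from compound 1 to compound 2 (0.77 log units; beyond the scatter), a 2.5-fold lower number from compound 2 to compound 3 (0.39 log units; beyond the scatter) and a 15-fold lower number from compound 1 to compound 3 (1.16 log units; beyond the scatter); each exchanges the substituent on the aryl group of the thiourea, so all three bear on what follows.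

Compound 4 `CCOc1ccc(NC(=S)N2CCC(C(O)(c3ccccc3)c3ccccc3)CC2)cc1C#N` differs from compound 2 by 3-cyano-4-ethoxyphenyl in place of 4-(trifluoromethyl)phenyl on an amide-type nitrogen. The measured steps show that swapping this aryl substituent shifts the number by modest to large amounts, with the alkoxy-bearing compound 1 highest and the amino-bearing compound 3 lowest. Compound 4 combines an ethoxy with a nitrile, a pairing absent from the measured set, so the direction cannot be read off; a modest move is expected, a 1.4-fold higher number from compound 2 to compound 4 (0.15 log units; within the scatter). Compound 4 is estimated at 250 nM, with a range from 80 nM to 800 nM.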

Compound 4, half-maximal inhibitory concentration: 323 nM
For compound 4 the middle estimate is 1.3-fold (0.11 log units) below the measured one; low and high end bracket the measured number.
By their numbers in this assay, from the lowest: compound 3; then compounds 2 and 4 (each within the scatter of the next); then compound 1.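

In this assay, placing 3-cyano-4-ethoxyphenyl on the amide-type nitrogen in place of 4-(trifluoromethyl)phenyl gives a result that stays level with compound 2 (step: a 1.8-fold higher number from compound 2 to compound 4 (0.26 log units; within the scatter)), so this position accepts an aryl group bearing both an ethoxy and a nitrile. The same aryl group separates clearly from the other two substituents (steps: a 3.3-fold lower number from compound 1 to compound 4 (0.51 log units; beyond the scatter); a 4.5-fold higher number from compound 3 to compound 4 (0.65 log units; beyond the scatter)), placing compound 4 inside the span set by compound 3 and compound 1. Oxygen attached to the aryl ring therefore does not by itself go with the highest number, though compound 4 also differs from compound 1 by its nitrile, and nothing at hand explains these differences.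

The ethoxy and nitrile enter together, so their separate contributions remain unresolved. Also open, from the compounds shown here alone, is how a propoxy chain or a dimethylamino group would read at this position.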